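Shortening the side chain of compound 1

A few compounds are considered here, and "the series" means these few. Any claim that something is new, unique, unknown or untested is made for them only; others in the source may bear on it.

Compound 1 `C=C(C)CCC[C@]1(C)C2=CCC[C@](C)(C[C@H](O)c3ccoc3)[C@H]2CC[C@H]1C`: 66000 nM
Compound 2 `C=C(C)CCC[C@]1(C)C2=CCC[C@](C)(C[C@H](O)C3=CC(=O)OC3O)[C@H]2CC[C@H]1C`: 3200 nM
Compound 3 `C=C(C)CCC[C@]1(C)C2=CCC[C@](C)(C[C@@H](O)C3=CC(=O)OC3O)[C@H]2CC[C@H]1C`: 3800 nM

In a functional assay on A549 cells (Homo sapiens) for antiproliferative activity, read by XTT assay, with a stated time of 72 h (a higher number here means a weaker inhibitor, a lower number a stronger inhibitor), compound 1 has the highest number of the three and is the weakest inhibitor measured. Both steps away from it are large: a 17-fold lower number from compound 1 to compound 3 (1.24 log units; beyond the scatter) and a 21-fold lower number from compound 1 to compound 2 (1.31 log units; beyond the scatter). Compound 4 `C=C(C)CC[C@]1(C)C2=CCC[C@](C)(C[C@H](O)c3ccoc3)[C@H]2CC[C@H]1C` differs from compound 1 in one place: 1-methylethenyl in place of 2-methylprop-2-en-1-yl on a saturated chain carbon, two bonds along the chain from a saturated ring carbon. Within the data shown here, none of the measured steps touches this chain; the two large ones replace the aromatic ring on the carbon bearing oxygen, and the remaining pair differs only in how one stereocentre is drawn, a 1.2-fold higher number from compound 2 to compound 3 (0.07 log units; within the scatter), within the scatter. Among the measured compounds shown here, with no measured step bearing on this change, the expected step of no change at the digits printed from compound 1 to compound 4 (within the scatter) is none beyond the scatter. Compound 4 is therefore estimated at 66000 nM, within 25000 nM to 180000 nM.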

Compound 4, half-maximal inhibitory concentration: 34000 nM
Beside the measured number, compound 4's estimate is 1.9-fold (0.29 log units) above it; low and high end bracket the measured number.
By their numbers in this assay, from the lowest: compounds 2 and 3 (each within the scatter of the next); then compounds 4 and 1 (each within the scatter of the next).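

Going from 2-methylprop-2-en-1-yl to 1-methylethenyl in this assay gives a 1.9-fold lower number from compound 1 to compound 4 (0.29 log units; within the scatter), the first reading on this side chain. One carbon can thus leave this chain with no change that stands clear of the scatter, unlike the large steps at the aromatic ring. No available evidence bears on this chain change.

On these data alone, whether a longer chain or a carboxylic acid at the chain end would shift the number remains open. So does whether the shorter chain behaves alike with the five-membered non-aromatic ring of compound 2.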